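A few compounds are considered here, and "the series" means these few. Any claim that something is new, unique, unknown or untested is made for them only; others in the source may bear on it.

Compound 1: `COc1ccc(-c2cccc(C(=O)N(C)C)c2)cc1S(=O)(=O)Nc1cccc(NCCCNC(=O)c2cccc(C)c2)c1` — 400 nM
Compound 2: `COc1ccc(-c2cncc(C(=O)N(C)C)c2)cc1S(=O)(=O)Nc1cccc(NCCNC(=O)c2cccc(C)c2)c1` — 7530 nM

In a functional assay on CHO-RD-HGA16 cells for agonist activity at Orexin/Hypocretin receptor type 1 (Homo sapiens), read by fluorescence and calcium flux, with a stated time of 30 min (a higher number here means that more compound is needed for the effect, a lower number that less compound is needed), compound 2 gives 7530 nM, the higher of the two numbers recorded; compound 1 gives 400 nM, but the two differ in more than one place, so only their values are compared here. Compound 3, `COc1ccc(-c2cccc(C(=O)N(C)C)n2)cc1S(=O)(=O)Nc1cccc(NCCNC(=O)c2cccc(C)c2)c1`, has not yet been measured. It differs from compound 2 by 6-(dimethylcarbamoyl)pyridin-2-yl in place of 5-(dimethylcarbamoyl)pyridin-3-yl on an aromatic carbon. Among the measured compounds shown here, no single-change step has been recorded, so the size of this change is unknown; a moderate shift in either direction, or none beyond the scatter, is expected. Compound 3 is estimated at 4000 nM, within a range of 1000 nM to 16000 nM. The expected step is a 1.9-fold lower number from compound 2 to compound 3 (0.27 log units; within the scatter).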

Compound 3, half-maximal effective concentration: 226 nM
Beside the measured number, compound 3's estimate is 18-fold (1.25 log units) above it; the measured number lies below the stated range.
By their numbers in this assay, from the lowest: compounds 3 and 1 (each within the scatter of the next); then compound 2.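

In this assay, among the compounds shown here, 6-(dimethylcarbamoyl)pyridin-2-yl in place of 5-(dimethylcarbamoyl)pyridin-3-yl gives a 33-fold lower number from compound 2 to compound 3 (1.52 log units; beyond the scatter) and is the first single-change step in this set. At this aromatic carbon, para to a methoxy group, the same atoms joined differently are enough for a large step. No measurement here accounts for its size.

The compounds shown leave open whether the lower number persists with the chain of compound 1. They also leave open what a carboxylic acid or a primary amide would do in place of the dimethylcarbamoyl group.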